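The compounds below may be only part of what the source reports. "The series", "measured", "known", "first", "only" and "open" are said of these compounds alone.

Working notes on the series. Compound 1 `COc1cc2c(cc1OC)[C@H](C)C(=O)N(C)C=C2` and compound 2 `COc1cc2c(cc1OC)[C@@H](C)C(=O)N(C)C=C2` are measured alongside compound 3 `C[C@H]1C(=O)N(C)C=Cc2ccccc21`. In a physicochemical assay for lipophilicity, at pH 7.4 (a higher number here means a more lipophilic compound, a lower number a more polar compound), compound 1 gives 3.4, compound 2 gives 3.4 and compound 3 gives 4.3. Compound 3 holds the highest of the three numbers, beyond the scatter from both others.

The next compound is compound 4 `CCc1ccc2c(c1)C=CN(C)C(=O)[C@@H]2C`, reached from compound 3 by one change: ethyl in place of hydrogen on an aromatic carbon.

Going by the values given here, the only measured step shows no change at the digits printed from compound 1 to compound 2 (within the scatter), and it concerns (the fact that compounds 1 and 2 differ only in the configuration as drawn). It therefore sets no size for a substitution on an aromatic carbon. Among the compounds with values here, no measured step replaces hydrogen in this way, so the estimate rests on the structural change alone and its range is kept wide.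

A rise beyond the scatter in this assay is expected, an estimated a number 0.80 log units higher from compound 3 to compound 4 (beyond the scatter). For compound 4 the expected value is 5.1, with an estimated range of 4.6 to 5.6.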

Compound 4, distribution coefficient: 5.9
Compound 4: the middle estimate sits 0.80 log units below what was measured; measured number above the stated range.
By their numbers in this assay, from the lowest: compounds 1 and 2 (each within the scatter of the next); then compound 3; then compound 4.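

In this assay, going by these compounds alone, ethyl in place of hydrogen on an aromatic carbon gives a number 1.60 log units higher from compound 3 to compound 4 (beyond the scatter) and is the first measured step that replaces hydrogen on the aromatic ring. Within the data shown here, it shows that a substitution at this place, meta to a fused ring and para to a fused ring, can move the number well beyond the scatter, whereas the only earlier step, a change of drawn configuration, moved nothing at the digits printed. No information given on the series accounts for the size of this step.

On these data alone, it remains open whether a carboxylic acid or an amine at the same place would move the number the other way. As far as these compounds go, a longer chain is equally open, as is the size of the ethyl step on the core of compound 1.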